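A Hydroxyl Replaces Fluorine in a Series at Its Limit

The compounds below may be only part of what the source reports. "The series", "measured", "known", "first", "only" and "open" are said of these compounds alone.

In a functional assay on MDA-MB-231 cells (Homo sapiens) for antiproliferative activity, read by MTT assay, with a stated time of 48 h (on this read-out lower numbers stand for stronger inhibition and higher numbers for weaker inhibition), compound 1 (`C/C(=C\CC/C(C)=C/CC[C@@H]1[C@@]2(C)CCC(=O)C(C)(C)[C@H]2CC[C@@]1(C)O)CC/C=C(\C)C(=O)OCc1cn(-c2ccccc2Cl)nn1`) gives > 150000 nM as a limit and not a number. Compound 2 (`C/C(=C\CC/C(C)=C/CC[C@@H]1[C@@]2(C)CCC(=O)C(C)(C)[C@H]2CC[C@@]1(C)O)CC/C=C(\C)C(=O)OCc1cn(-c2ccccc2F)nn1`) gives > 150000 nM as a limit too. Among the compounds with values here, both sit at the limit of > 150000 nM in this assay, at which 2 of the 2 values shown sit, and the sole measured step is a step that the two limits leave unreadable from compound 1 to compound 2 with fluoro in place of chloro. Compound 3 (`C/C(=C\CC/C(C)=C/CC[C@@H]1[C@@]2(C)CCC(=O)C(C)(C)[C@H]2CC[C@@]1(C)O)CC/C=C(\C)C(=O)OCc1cn(-c2cccc(O)c2)nn1`) carries 3-hydroxyphenyl in place of 2-fluorophenyl on an aromatic nitrogen. The measured step offers no size to carry over, so no shift beyond the scatter is expected in this assay in either direction. The expected change is a number no higher from compound 2 to compound 3 (the limit leaves the size open) on this estimate. For compound 3 the estimated value is 150000 nM with an expected range from 50000 nM to 300000 nM in this assay.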

Compound 3, half-maximal inhibitory concentration: 139000 nM
Compound 3: middle estimate off by 1.1-fold (0.03 log units), on the high side; the measured number falls inside the stated range.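

In this assay, within the data shown here, compound 3 gives 139000 nM, the only one of the three values that is a number and not a limit. With 3-hydroxyphenyl on the aromatic nitrogen, the steps read an at least 1.0-fold lower number from compound 2 to compound 3 (0.03 log units; that floor lies within the scatter) and an at least 1.0-fold lower number from compound 1 to compound 3 (0.03 log units; that floor lies within the scatter). Only these floors can be read, and the step between compound 1 and compound 2 cannot be read at all: the limit of > 150000 nM in this assay, at which 2 of the 3 values shown sit.

Compound 3 differs from compound 2 in both the group and its place on the phenyl ring, and the compounds shown do not separate the two. Going by these compounds, how an amine or a carboxylic acid would read on that ring also stays open.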